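A few compounds are considered here, and "the series" means these few. Any claim that something is new, unique, unknown or untested is made for them only; others in the source may bear on it.

Working notes on the series, read in a functional assay for inhibition, with Homo sapiens as the target; on this read-out lower numbers stand for stronger inhibition and higher numbers for weaker inhibition. Compound 1 (`O=C(O)CCNC(=O)c1ccc2c(c1)C(=O)N(CCC1CCNCC1)C2`) gives 27 nM, compound 2 (`CCCCNC(=O)N[C@@H](CNC(=O)c1ccc2c(c1)C(=O)N(CCC1CCNCC1)C2)C(=O)O`) gives 16 nM, and compound 3 (`O=C(NC[C@H](NS(=O)(=O)c1cccs1)C(=O)O)c1ccc2c(c1)C(=O)N(CCC1CCNCC1)C2`) gives 7 nM. Compound 3 has the lowest number of the three, and its gaps to both others lie beyond the scatter.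

Compound 4 (`O=C(NC[C@H](NS(=O)(=O)c1cccnc1)C(=O)O)c1ccc2c(c1)C(=O)N(CCC1CCNCC1)C2`) is still unmeasured. It differs from compound 3 by pyridin-3-yl in place of thiophen-2-yl on a sulfonyl sulfur. Among the measured compounds shown here, no measured pair varies this group alone, so the evidence is indirect. Adding the whole ((thiophen-2-yl)sulfonyl)amino group gave a 3.9-fold lower number from compound 1 to compound 3 (0.59 log units; beyond the scatter), and the butylcarbamoyl group on the same chain gave a 1.7-fold lower number from compound 1 to compound 2 (0.23 log units; within the scatter). Exchanging butylcarbamoyl for (thiophen-2-yl)sulfonyl on the amine nitrogen gave a 2.3-fold lower number from compound 2 to compound 3 (0.36 log units; beyond the scatter).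

These steps are small even though they change far more of the structure than one aromatic ring does, so in this assay no step beyond the scatter is expected, with a slight lean towards a higher number. The expected step is a 1.4-fold higher number from compound 3 to compound 4 (0.15 log units; within the scatter). For compound 4 the estimated value is 10 nM, with an expected range of 4 nM to 25 nM.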

Compound 4, half-maximal inhibitory concentration: 15 nM
For compound 4 the middle estimate is 1.5-fold (0.18 log units) below the measured one; the measured number falls inside the stated range.
By their numbers in this assay, from the lowest: compound 3; then compounds 4, 2 and 1 (each within the scatter of the next).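

In this assay the ring on the sulfonyl sulfur counts on its own, with a 2.1-fold higher number from compound 3 to compound 4 (0.33 log units; beyond the scatter) for a single ring exchange, so this position is not indifferent to pyridin-3-yl in place of thiophen-2-yl. The gain seen with the thiophen-2-yl sulfonamide does not carry over to the whole sulfonamide class: the series shows a 1.1-fold lower number from compound 2 to compound 4 (0.03 log units; within the scatter) and also a 1.8-fold lower number from compound 1 to compound 4 (0.26 log units; within the scatter) and both steps lie within the scatter, so ((pyridin-3-yl)sulfonyl)amino on the chain cannot be told apart from the butylcarbamoyl-bearing amine or from hydrogen at that carbon. Nothing measured here accounts for the difference between the two rings.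

Ring size and the identity of the hetero atom change together in this pair, and phenyl or thiophen-3-yl on the sulfonyl sulfur would separate the two. Also open is what the carboxylic acid on the chain contributes, as every compound shown carries it, and a primary amide or methyl ester in its place would address that.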